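Iodo to Ethynyl: An Expected Step in Myeloperoxidase Inhibition

The source may hold more compounds than are shown below. What is called first, only, known or untested is meant among the compounds shown, and "the series" means these compounds.

Of the compounds shown here, two sharing one core have so far been measured in an assay on isolated protein (urine) for inhibition of Myeloperoxidase (Homo sapiens), read by spectrophotometry; on this read-out lower numbers stand for stronger inhibition and higher numbers for weaker inhibition. Compound 1 `COc1c2ccccc2nn1C(C)C` gives 704 nM in this assay. Compound 2 `COc1c2ccccc2nn1-c1ccc(I)cc1` gives 2000 nM, the higher of the two numbers; its nearest neighbour is compound 1, whose number is lower by a margin beyond the usual scatter. Compound 3 `C#Cc1ccc(-n2nc3ccccc3c2OC)cc1` has not yet been measured in this assay. The difference from its predecessor is confined to one place: ethynyl in place of iodo on an aromatic carbon. For the measured compounds named here, no pair of measured compounds differing in a single place is available, so there is no measured step to lean on here. The expectation is that the replacement moves the number only slightly, an expected step of a 1.3-fold lower number from compound 2 to compound 3 (0.12 log units; within the scatter) that stays within the scatter. Compound 3 is therefore estimated at 1500 nM, with a range from 500 nM to 5000 nM.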

Compound 3, half-maximal inhibitory concentration: 1100 nM
The estimate for compound 3 lay 1.4-fold (0.13 log units) above the measured number, within the range that was stated.
By their numbers in this assay, from the lowest: compounds 1, 3 and 2 (each within the scatter of the next, the first and the last beyond it).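

For the compounds shown here, with this assay there is now a first step between compounds that differ in one place, and a 1.8-fold lower number from compound 2 to compound 3 (0.26 log units; within the scatter) is what that step amounts to. On this aromatic carbon, para to a large group, iodo and ethynyl therefore cannot be told apart on this read-out, even though a single iodine atom gives way to two carbon atoms and a triple bond outside aromatic rings. No measurement shown here bears on why the two groups read alike. The compounds shown leave open whether an amine, a carboxylic acid or a longer chain on this aromatic carbon would also stay within the scatter of these two groups. They also leave open whether the same exchange of iodo for ethynyl would give a comparable step on another core.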